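The source may report more compounds than this note shows. Statements on the series, on what has been measured and on what is new or still open speak of the compounds shown alone.

Measured so far:
- compound 1, `CCOc1ccc(NC2=CC(=O)c3nc4n(c3C2=O)[C@H]2OC[C@@H](O)[C@H]2OC4)cc1`: 3110 nM in a functional assay on HeLa cells (Homo sapiens) for inhibition, read by sulforhodamine B assay; on this read-out lower numbers stand for stronger inhibition and higher numbers for weaker inhibition
- compound 2, `O=C1C(NCc2ccccc2)=CC(=O)c2c1nc1n2[C@H]2OC[C@@H](O)[C@H]2OC1`: 11000 nM in this assay

Only these two numbers are known. Compound 1 has the lower of them, and the number for compound 2 lies beyond the usual scatter of this assay, so compound 1 is the stronger inhibitor of the pair. Compound 2 differs from compound 1 in more than one place, so its value gives no guide to any single change.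

Compound 3, `O=C1C=C(Nc2cccc(Cl)c2)C(=O)c2c1nc1n2[C@H]2OC[C@@H](O)[C@H]2OC1`, has not yet been measured. It differs from compound 1 in one place: 3-chlorophenyl in place of 4-ethoxyphenyl on an amine nitrogen. Among the compounds with values here, no measured pair shows what this kind of exchange does, so the expectation rests on compound 1 alone. The step is expected to be small, in either direction or none beyond the scatter, as a 1.0-fold lower number from compound 1 to compound 3 (0.02 log units; within the scatter). Compound 3 is estimated at 3000 nM, with a range from 1000 nM to 10000 nM.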

Compound 3, half-maximal inhibitory concentration: 6040 nM
Beside the measured number, compound 3's estimate is 2.0-fold (0.30 log units) below it; low and high end bracket the measured number.
By their numbers in this assay, from the lowest: compounds 1, 3 and 2 (each within the scatter of the next, the first and the last beyond it).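

In this assay, within the data shown here, placing 3-chlorophenyl on the amine nitrogen in place of 4-ethoxyphenyl gives a 1.9-fold higher number from compound 1 to compound 3 (0.29 log units; within the scatter), the first comparison at this position in which only one place differs. The two groups share a six-membered carbon ring but carry different substituents at different ring positions, and this exchange still does not separate the two compounds on this read-out. No measurement is available that would explain this result.

A plain phenyl group would help to separate the effect of removing the ethoxy group from that of adding the chlorine, but the compounds shown leave this open. They also leave open whether an amine or a carboxylic acid on this ring would shift the number beyond the scatter.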